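The compounds below may be only part of what the source reports. "The series", "measured", "known", "first", "only" and "open" are said of these compounds alone.

Within the data shown here, compound 3 `Cc1cc(NCc2ccccn2)n2ncc(-c3ccco3)c2n1` is the only member of this set with a number of its own in a physicochemical assay for solubility, read by HPLC, using the shake flask method, measured as kinetic solubility, with a stated time of 2 h, at pH 7.4 (a lower number here means a less soluble compound, a higher number a more soluble compound), where compound 3 gives 48800 nM. Compound 1 `COc1ccc(-c2cnn3c(NCc4ccccn4)cc(C)nc23)cc1` sits at a limit, giving < 5000 nM in this assay. Compound 2 `Cc1cc(NCc2ccccn2)n2ncc(-c3ccc(F)c(Cl)c3)c2n1` likewise sits at a limit, giving < 5000 nM in this assay; this is the limit described as the limit of < 5000 nM in this assay, at which 2 of the 3 values shown sit. Compound 3 is therefore the most soluble compound shown, since the steps of an at least 9.7-fold higher number from compound 1 to compound 3 (0.98 log units; beyond the scatter) and an at least 9.7-fold higher number from compound 2 to compound 3 (0.98 log units; beyond the scatter) both lie beyond the scatter.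

Compound 4 `Cc1cc(NCc2ccccn2)n2ncc(C3=CCOCC3)c2n1` differs from compound 3 by a group of 6 heavy atoms (5 carbon, 1 oxygen; one six-membered non-aromatic ring with 1 hetero atom) in place of a group of 5 heavy atoms (4 carbon, 1 oxygen; one five-membered aromatic ring with 1 hetero atom), on an aromatic carbon. Neither measured step covers this kind of change: both an at least 9.7-fold higher number from compound 1 to compound 3 (0.98 log units; beyond the scatter) and an at least 9.7-fold higher number from compound 2 to compound 3 (0.98 log units; beyond the scatter) describe the entry of furan-2-yl in place of a phenyl-type ring, whereas here furan-2-yl itself leaves. Among the measured compounds shown here, with no measured step bearing directly on it, compound 4 is expected to stay near compound 3 in this assay, the estimated step of a 1.2-fold higher number from compound 3 to compound 4 (0.09 log units; within the scatter) lying within the scatter. Compound 4 is accordingly estimated at 60000 nM, with a range from 20000 nM to 180000 nM.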

Compound 4, solubility: 171000 nM
Compound 4: the middle estimate sits 2.9-fold (0.45 log units) below what was measured; low and high end bracket the measured number.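

At this place, on an aromatic carbon of the five-membered aromatic ring, the earlier compounds carried only aromatic rings, and the six-membered non-aromatic ring with 1 hetero atom now gives a first reading without one: in this assay there is a 3.5-fold higher number from compound 3 to compound 4 (0.54 log units; beyond the scatter), which makes compound 4 the compound with the highest number of the four shown. The gaps to the two phenyl-bearing compounds are wider still, at an at least 34-fold higher number from compound 2 to compound 4 (1.53 log units; beyond the scatter) and an at least 34-fold higher number from compound 1 to compound 4 (1.53 log units; beyond the scatter). Both of these steps start from a value that is a limit and not a number: the limit of < 5000 nM in this assay, at which 2 of the 4 values shown sit.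

With only one non-aromatic ring shown, the part played by its double bond remains open. From the compounds shown here alone, how a tetrahydropyran-4-yl ring, or a piperidin-4-yl ring with a ring amine in place of the oxygen, would read in this assay also remains open.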